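The source may report more compounds than this note shows. Statements on the series, on what has been measured and on what is new or still open speak of the compounds shown alone.

Values in a functional assay on the whole organism with Mus musculus as the target; on this read-out lower numbers stand for an effect already at smaller amounts and higher numbers for an effect only at larger amounts of compound:
- Compound 1 `COc1cc2c(cc1OC)C(c1ccc(Br)cc1)=NN(C)C(=S)C2`: 105 umol/kg
- Compound 2 `COc1cc2c(cc1OC)C(c1ccccc1)=NNC(=O)C2`: 33.9 umol/kg
- Compound 3 `COc1cc2c(cc1OC)C(c1cccc([N+](=O)[O-])c1)=NNC(=O)C2`: > 120 umol/kg, a limit of the assay and not a number

Compound 2, at 33.9 umol/kg, has the lower of the two actual numbers, and compound 1 stands higher. Compound 4 `COc1cc2c(cc1OC)C(c1ccc(Cl)cc1)=NNC(=O)C2` is compound 2 with one change: chloro in place of hydrogen on an aromatic carbon, that is, phenyl to 4-chlorophenyl. Among the measured compounds shown here, only one measured step bears on this, a different group on an aromatic carbon: an at least 3.5-fold higher number from compound 2 to compound 3 (0.54 log units; beyond the scatter). It is a single step with a different substituent, so only a small rise in the number is expected, probably not clearly beyond the scatter. The expected change is a 1.3-fold higher number from compound 2 to compound 4 (0.12 log units; within the scatter). For compound 4 the estimated value is 45 umol/kg, with an expected range of 18 umol/kg to 110 umol/kg.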

Compound 4, dose for half-maximal effect: 102 umol/kg
Compound 4: middle estimate off by 2.3-fold (0.36 log units), on the low side; low and high end bracket the measured number.
By their numbers in this assay, from the lowest: compound 2; then compounds 4 and 1 (each within the scatter of the next). At a limit, above all of these: compound 3.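

In this assay, phenyl to 4-chlorophenyl gives a 3.0-fold higher number from compound 2 to compound 4 (0.48 log units; beyond the scatter). Among the compounds shown here, a single chlorine atom on this aromatic carbon, para to a large group, is therefore enough to move the number beyond the scatter, which the earlier compounds could not show as a measured size. Nothing available explains this rise.

Compound 3, at > 120 umol/kg, is a limit and not a number. Still open, going by these compounds, is how fluoro, an amine or a carboxylic acid on this same aromatic carbon would read against compound 2.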